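This account rests on a few compounds, and the source may have more. Where it says the series, first, only, none or still open, it means among the compounds named here.

Measured so far:
- compound 1, `COc1cc(-c2nccn2C(C)C)cc(OC)c1OC`: > 100000 nM
- compound 2, `COc1cc(-c2nccn2-c2ccc3sccc3c2)cc(OC)c1OC`: 1400 nM
- compound 3, `COc1cc(-c2nccn2-c2ccc3cc[nH]c3c2)cc(OC)c1OC`: 4800 nM

Compound 1, `COc1cc(-c2nccn2C(C)C)cc(OC)c1OC`, carries an isopropyl group on one nitrogen of its shared core. In a functional assay on HeLa cells (Homo sapiens) for antiproliferative activity, read by MTT assay, with a stated time of 72 h (a higher number here means a weaker inhibitor, a lower number a stronger inhibitor), compound 1 gives only > 100000 nM, which is a limit of the assay and not a number; the only thing known is the limit of > 100000 nM in this assay, at which 1 of the 3 values shown sits. Compound 2, `COc1cc(-c2nccn2-c2ccc3sccc3c2)cc(OC)c1OC`, gives 1400 nM in this assay. Compound 3, `COc1cc(-c2nccn2-c2ccc3cc[nH]c3c2)cc(OC)c1OC`, gives 4800 nM. The numbers for compound 2 and compound 3 sit far below the limit found for compound 1, and in their structures the same nitrogen carries something other than isopropyl.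

The new compound 4, `COc1ccc(-n2ccnc2-c2cc(OC)c(OC)c(OC)c2)cc1`, keeps the shared core and changes only what that nitrogen carries: 4-methoxyphenyl in place of isopropyl on an aromatic nitrogen. Among the compounds with values here, no step between measured compounds covers this exact change, so the expected size can only be read from how compound 2 and compound 3 stand against compound 1. On that basis a large step toward stronger inhibition is expected, well beyond the scatter, of about an at least 66-fold lower number from compound 1 to compound 4 (1.82 log units; beyond the scatter). Compound 4 is therefore estimated to give 1500 nM in this assay, within a range of 300 nM to 8000 nM.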

Compound 4, half-maximal inhibitory concentration: 1200 nM
Compound 4: the middle estimate sits 1.3-fold (0.10 log units) above what was measured; low and high end bracket the measured number.
By their numbers in this assay, from the lowest: compounds 4 and 2 (each within the scatter of the next); then compound 3. At a limit, above all of these: compound 1.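

In this assay, within the data shown here, 4-methoxyphenyl in place of isopropyl on this aromatic nitrogen gives an at least 83-fold lower number from compound 1 to compound 4 (1.92 log units; beyond the scatter), the first step at this position that can be read between two compounds differing in one place only. The entering group holds just one six-membered aromatic ring of carbon only, and with it compound 4 gives 1200 nM, within the scatter of compound 2 at 1400 nM, so the differently built group of compound 2 is not needed to reach a value of this size. The true size of the step remains unknown because compound 1 has only a limit and not a number: the limit of > 100000 nM in this assay, at which 1 of the 4 values shown sits.

The compounds shown leave open whether the aromatic ring alone accounts for the step or the methoxy group also contributes, a question that a plain phenyl or a 4-hydroxyphenyl on this nitrogen would address. They also leave open how this assay would read with an amine or a carboxylic acid on that ring, or with a benzyl group on the nitrogen.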